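The source may report more compounds than this note shows. Statements on the series, on what has been measured and on what is new or still open speak of the compounds shown alone.

Within the data shown here, compound 2 `COC(=O)C(=O)NC1=C(C#N)C2C(N3CCCC3)CCCCN2C(=O)N1c1ccccc1` stands at the top of the two numbers so far. Among the measured compounds shown here, in a functional assay on the whole organism (strain albino) for inhibition, with Rattus norvegicus as the target, read by paw edema, with stated times of 1 h and 2 h, at a dose of 20 mmol/kg by the intraperitoneal route (a lower number here means less inhibition, a higher number more inhibition at the dose given (going by the name of the read-out)), compound 2 gives 85.6%, while compound 1 `COc1ccc(/C=N/C2=C(C#N)C3C(N4CCCC4)CCCCN3C(=O)N2c2ccccc2)cc1` gives 71.6%; the single step between them, a number 14 percentage points higher from compound 1 to compound 2 (beyond the scatter), exchanged one substituent on the double-bonded ring carbon for another. Compound 3 `N#CC1=C(N)N(c2ccccc2)C(=O)N2CCCCC(N3CCCC3)C12` is not yet measured. It differs from compound 2 by hydrogen in place of (methoxycarbonyl)carbonyl on an amine nitrogen, so the amine nitrogen that bore a substituent in both measured compounds now carries only hydrogen. For the measured compounds named here, that step bears on compound 3 only loosely: it compared two different groups at that position and showed a modest change, yet neither compound lacks a group there, so no measured step tells what removal does. Given that the modest swap of groups moved the number by the modest amount seen, the author expects the loss of the whole group to move this assay by a comparable, modest amount, most likely downward, as a number 17.6 percentage points lower from compound 2 to compound 3 (beyond the scatter). Compound 3 is therefore estimated at 68%, within a range of 48% to 86%.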

Compound 3, a percentage reported as inhibition, in the whole organism at one dose (the size of the read-out at that dose, not a potency): 86.9%
Compound 3: middle estimate off by 18.9 percentage points, on the low side; measured number above the stated range.
By their numbers in this assay, from the lowest: compound 1; then compounds 2 and 3 (each within the scatter of the next).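

In this assay there is a number 1.3 percentage points higher from compound 2 to compound 3 (within the scatter) when the (methoxycarbonyl)carbonyl on the amine nitrogen gives way to hydrogen, so the whole group can go without the reading leaving the usual scatter, which the swap of one group for another could not show. Set against the free amino form, the group with the six-membered aromatic ring of compound 1 stands apart, with a number 15.3 percentage points higher from compound 1 to compound 3 (beyond the scatter), so among these three compounds only that group separates from the others, while the amino and ((methoxycarbonyl)carbonyl)amino forms cannot be told apart at this dose. No measurement at hand explains why removing the group leaves the reading where it was.

On these data alone, it remains open whether other groups on this nitrogen, such as a plain acetyl, a longer alkyl chain or a carboxylic acid, would read like the free amine or like the group of compound 1. Each compound is also seen at a single dose, so the shared reading of compound 2 and compound 3 says nothing about whether the two would still match at lower doses.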